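Swapping the Amide Phenyl for a Chloropyridinyl Group

The compounds below may be only part of what the source reports. "The series", "measured", "known", "first", "only" and "open" are said of these compounds alone.

Of the compounds shown here, three share one core and have been measured in a functional assay on U-87MG ATCC cells for inhibition, with U-87 MG (Homo sapiens) as the target, read by MTT assay, with a stated time of 72 h; a lower number here means a stronger inhibitor, a higher number a weaker inhibitor. Compound 1 `Cc1noc(C)c1-c1cnc(N)c(Oc2ccc(C(=O)Nc3ccccc3)cc2)n1` gives 26600 nM. Compound 2 `Cc1noc(C)c1-c1cnc(N)c(Oc2ccc(C(=O)Nc3cccc(Cl)n3)cc2)n1` gives 64100 nM, and a 2.4-fold higher number from compound 1 to compound 2 (0.38 log units; beyond the scatter). Compound 3 `Cn1cc(-c2cnc(N)c(Oc3ccc(C(=O)Nc4ccccc4)cc3)n2)cn1` gives 17700 nM; this is the lowest of the three numbers, with compound 1 nearest and within the scatter, and compound 2 furthest and beyond it. The step of a 1.5-fold lower number from compound 1 to compound 3 (0.18 log units; within the scatter) shows that the exchange on the aromatic carbon changes little.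

Compound 4 `Cn1cc(-c2cnc(N)c(Oc3ccc(C(=O)Nc4cc(Cl)ccn4)cc3)n2)cn1` has not yet been measured. It differs from compound 3 by 4-chloropyridin-2-yl in place of phenyl on an amide-type nitrogen. Among the compounds with values here, the only measured step that bears on it is the one from compound 1 to compound 2, where a chloropyridinyl group also replaced the phenyl on the amide-type nitrogen, with a modest rise in this assay. A rise of similar size is therefore expected, a 2.0-fold higher number from compound 3 to compound 4 (0.30 log units; within the scatter). For compound 4 the expected value in this assay is 35000 nM, within a range from 12000 nM to 100000 nM.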

Compound 4, half-maximal inhibitory concentration: 47900 nM
Compound 4: middle estimate off by 1.4-fold (0.14 log units), on the low side, and the stated range covers the measured number.
By their numbers in this assay, from the lowest: compounds 3, 1, 4 and 2 (each within the scatter of the next, the first and the last beyond it).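

On the compound carrying 1-methyl-1H-pyrazol-4-yl on the aromatic carbon, putting 4-chloropyridin-2-yl in place of phenyl on the amide-type nitrogen gives a 2.7-fold higher number from compound 3 to compound 4 (0.43 log units; beyond the scatter) in this assay. Within the data shown here, the rise is therefore not confined to the one earlier pair, which carried 3,5-dimethyl-1,2-oxazol-4-yl and 6-chloropyridin-2-yl and gave a 2.4-fold higher number from compound 1 to compound 2 (0.38 log units; beyond the scatter); both steps of this kind go the same way, and neither goes against the pattern. Nothing available explains the rise at this position.

The compounds shown leave open whether the rise goes with the ring nitrogen or with the chlorine, since neither an unsubstituted pyridin-2-yl group nor a chlorophenyl group appears among them. They also leave open how an amine or a carboxylic acid on this ring would read in this assay.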